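This account rests on a few compounds, and the source may have more. Where it says the series, first, only, none or still open, it means among the compounds named here.

Compound 1, `COc1nc(C)c(Nc2nc(Cl)cn([C@H](COC(=O)Nc3ccc(Cl)cc3Cl)C3CC3)c2=O)cc1C`, and compound 2, `COc1nc(C)c(Nc2nc(Cl)cn([C@H](COC(=O)Nc3cc(Cl)cc(Cl)c3)C3CC3)c2=O)cc1C`, share one core and differ only in which dichlorophenyl sits on the amide-type nitrogen. In an assay on frontal cortex for displacement of a labelled ligand from corticotropin-releasing factor receptor 1 (Rattus norvegicus), with a stated time of 2 h (on this read-out higher numbers stand for weaker inhibition and lower numbers for stronger inhibition), compound 1 gives 1.7 nM, and compound 2 gives 1.7 nM. The step of no change at the digits printed from compound 1 to compound 2 (within the scatter) shows that 3,5-dichlorophenyl in place of 2,4-dichlorophenyl on an amide-type nitrogen leaves the result unchanged, so compound 2 stands level with compound 1 at the digits shown. Compound 3, `CCCNC(=O)OC[C@H](C1CC1)n1cc(Cl)nc(Nc2cc(C)c(OC)nc2C)c1=O`, is the next member and has not yet been measured in this assay. Its difference from compound 2 is propyl in place of 3,5-dichlorophenyl on an amide-type nitrogen. For the measured compounds named here, no measured step trades an aromatic ring for a chain at this position; the one recorded step, no change at the digits printed from compound 1 to compound 2 (within the scatter), only rearranged chlorines on a ring that is itself removed here, so it bears loosely on the question at hand. For compound 3 the expected step is a 3.5-fold higher number from compound 2 to compound 3 (0.55 log units; beyond the scatter), a modest weakening carried with wide uncertainty. The estimate for compound 3 in this assay is 6 nM, within a range from 1.5 nM to 30 nM.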

Compound 3, half-maximal inhibitory concentration: 10 nM
Compound 3: the middle estimate sits 1.7-fold (0.22 log units) below what was measured, and the stated range covers the measured number.
By their numbers in this assay, from the lowest: compounds 1 and 2 (each within the scatter of the next); then compound 3.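

In this assay, propyl on the amide-type nitrogen gives a 5.9-fold higher number from compound 2 to compound 3 (0.77 log units; beyond the scatter), and the same exchange starting from the other dichlorophenyl gives a 5.9-fold higher number from compound 1 to compound 3 (0.77 log units; beyond the scatter). The position therefore responds to removal of the whole aromatic ring, whereas moving the chlorines around that ring had left the two values level. The change is modest, however, and compound 3, with propyl and no ring on this nitrogen, still gives 10 nM, so the dichlorophenyl ring is not needed for a reading in this range, although nothing shown here accounts for the size of the step.

The compounds shown cannot separate the loss of the ring from the loss of its two chlorines, a question that an unsubstituted phenyl on this nitrogen would address. Also open, as far as these compounds go, is how a longer chain such as hexyl, a saturated ring such as cyclohexyl, a benzyl group, or a propyl chain ending in an amine or a carboxylic acid would read at this position.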